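The compounds below may be only part of what the source reports. "The series", "measured", "known", "first", "only" and "open" are said of these compounds alone.

Measured compounds:
compound 1 `COc1cc(Cl)c(C(=O)N=C(N)N)cc1S(C)(=O)=O`, 40 nM
compound 2 `Cc1cc(N2CCC(N)CC2)c(S(C)(=O)=O)cc1C(=O)N=C(N)N`, 9.8 nM

In a functional assay for inhibition of sodium/hydrogen exchanger (Oryctolagus cuniculus) (on this read-out lower numbers stand for stronger inhibition and higher numbers for weaker inhibition), compound 2 holds the lowest number of the two, and the number of compound 1 lies higher by more than the scatter of repeated measurements. For the measured compounds named here, no single-point step between the two measured compounds is available, so compound 3 `CS(=O)(=O)c1cc(C(=O)N=C(N)N)c(Cl)cc1N1CCC(N)CC1` is judged from compound 2 alone. The change is chloro in place of methyl on an aromatic carbon. Going by the values given here, with no comparable step on hand, compound 3 is expected to stay close to compound 2, with the estimated step of a 1.1-fold higher number from compound 2 to compound 3 (0.05 log units; within the scatter) not beyond the scatter. Compound 3 is thus estimated at 11 nM in this assay, with a range from 4 nM to 30 nM.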

Compound 3, half-maximal inhibitory concentration: 20 nM
Estimate against measurement, compound 3: 1.8-fold (0.26 log units) below; measured number inside the range.
By their numbers in this assay, from the lowest: compound 2; then compounds 3 and 1 (each within the scatter of the next).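

In this assay, the aromatic carbon para to the methylsulfonyl group responds modestly to its substituent: chloro in place of methyl gives (a 2.0-fold higher number from compound 2 to compound 3 (0.31 log units; beyond the scatter)). With chloro held at that carbon, 4-aminopiperidin-1-yl in place of methoxy gives (a 2.0-fold lower number from compound 1 to compound 3 (0.30 log units; within the scatter)), so that exchange cannot be told from repeat-measurement noise in this pair. No measurement at hand bears on the reason for either step. Open, from the compounds shown here alone, is how a nitrile, a fluoro or a primary amine at this position would compare with methyl, and whether the exchange of methoxy for 4-aminopiperidin-1-yl reads the same with methyl in place of chloro.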